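The source may hold more compounds than are shown below. What is called first, only, known or untested is meant among the compounds shown, and "the series" means these compounds.

The study asks how Jurkat cells respond when a compound is present, and the read-out is a functional assay on Jurkat cells (Homo sapiens) for activation, with a stated time of 24 h; on this read-out lower numbers stand for an effect already at smaller amounts and higher numbers for an effect only at larger amounts of compound. Two compounds carry the same core, a hydroxyphenyl methylamine attached to a biphenyl-type scaffold. Compound 1, `Oc1ccccc1CNc1ccc(-c2ccccc2Cl)cc1`, is recorded in this assay as "not active" (no number reported), with no number given. Within the data shown here, compound 2, `Cc1ccccc1-c1ccc(NCc2ccccc2O)cc1`, gives in this assay 5220 nM; this is the only numerical value in the set, so compound 2 stands alone as the sole reference point, with no second number to rank it against.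

Compound 3, `Oc1ccccc1CNc1ccc(C2CCCCC2)cc1`, has not yet been measured in this assay. It differs from compound 2 in one place: cyclohexyl in place of 2-methylphenyl on an aromatic carbon. Among the measured compounds shown here, no measured pair in the set shows what such a change does, so the size and direction of the step can only be guessed.

The author expects compound 3 to sit close to compound 2 in this assay, perhaps somewhat weaker, and estimates the step as a 1.5-fold higher number from compound 2 to compound 3 (0.19 log units; within the scatter). The estimated value for compound 3 in this assay is 8000 nM, with a likely range from 2500 nM to 25000 nM.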

Compound 3, half-maximal effective concentration: 8800 nM
Estimate against measurement, compound 3: 1.1-fold (0.04 log units) below; the measured number falls inside the stated range.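

Among these compounds, exchanging 2-methylphenyl for cyclohexyl gives a 1.7-fold higher number from compound 2 to compound 3 (0.23 log units; within the scatter) in this assay and is the first step in the set that can be read, and it stays within the usual scatter. It shows that a six-membered aromatic ring of carbon only is not needed on this aromatic carbon for a number to be recorded, since a six-membered non-aromatic ring of carbon only also gives one, while compound 1, which has the aromatic ring, is recorded as "not active" (no number reported) in the same assay, so the aromatic ring alone does not ensure a number. Nothing in the data shown explains why these two rings give values so close together or what sets compound 1 apart.

On these data alone, what remains open is whether any ring is needed at this place, or whether a longer alkyl chain, a morpholine ring or a carboxylic acid on the same aromatic carbon would also give a number. Equally open, as far as these compounds go, is what a methoxy group in place of the hydroxyl of the shared core would do to the read-out.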